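The compounds below may be only part of what the source reports. "The series", "measured", "known", "first", "only" and "open" are said of these compounds alone.

Working notes on the trifluoromethyl-bearing series.

Compound 1 `CNC(=O)Cn1nc(N)c2c(C(F)(F)F)cc(-c3ccccc3)nc21` and compound 2 `CCCNC(=O)Cn1nc(N)c2c(C(F)(F)F)cc(-c3ccccc3)nc21` share the core with compound 3 `Nc1nn(CC(=O)NC2CC2)c2nc(-c3ccccc3)cc(C(F)(F)F)c12` and differ only at the amide-type nitrogen. In a functional assay on HeLa cells (Homo sapiens) for cytotoxicity, read by MTT assay, with a stated time of 24 h (on this read-out lower numbers stand for stronger inhibition and higher numbers for weaker inhibition), compound 1 gives 12200 nM and compound 2 gives 15900 nM; the step of a 1.3-fold higher number from compound 1 to compound 2 (0.12 log units; within the scatter) is the only one measured, and it is within the scatter, so ethyl in place of hydrogen on a saturated chain carbon bound to an amide-type nitrogen leaves the read-out unchanged. Compound 3 carries a cyclopropylamino group on the carbonyl carbon and is reported in this assay as "not active" (no number reported), with no number attached, so compound 3 cannot be placed against compound 1 or compound 2 on a scale.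

Compound 4 `Nc1nn(CC(=O)N2CCCC2)c2nc(-c3ccccc3)cc(C(F)(F)F)c12` is not yet measured. The change from compound 3 to compound 4 is pyrrolidin-1-yl in place of cyclopropylamino on a carbonyl carbon. The measured step from compound 1 to compound 2 also alters what sits at the amide-type nitrogen and was flat, which suggests no shift beyond the scatter from such a change, but compound 3 offers no number to shift from. Compound 4 is therefore expected to remain weak, roughly where compound 1 and compound 2 stand or weaker, and it is estimated at 30000 nM with a range from 10000 nM to 100000 nM.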

Compound 4, half-maximal inhibitory concentration: 16100 nM
Compound 4: middle estimate off by 1.9-fold (0.27 log units), on the high side; low and high end bracket the measured number.
By their numbers in this assay, from the lowest: compounds 1, 2 and 4 (each within the scatter of the next).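

In this assay, pyrrolidin-1-yl on the carbonyl carbon reads level with the open-chain amides, with steps of a 1.0-fold higher number from compound 2 to compound 4 (0.01 log units; within the scatter) and a 1.3-fold higher number from compound 1 to compound 4 (0.12 log units; within the scatter). Pyrrolidin-1-yl carries no hydrogen-bond donor, so among compounds 1, 2 and 4 a number in this range does not require the amide hydrogen; compound 3, reported as not active, stands apart from these three, and steps involving it cannot be read. No measurement available here offers an explanation for the difference between compound 3 and the other three.

On these data alone, whether any group at this place moves the read-out beyond the scatter stays open, and piperidin-1-yl, morpholin-4-yl, a longer chain or a carboxylic acid in place of the amide would bear on that. A cyclobutylamino group would show whether the reading of compound 3 is particular to cyclopropylamino.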